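The source may hold more compounds than are shown below. What is called first, only, known or untested is meant among the compounds shown, and "the series" means these compounds.

Measured so far in an assay on a protein complex for displacement of a labelled ligand from CDK8/Cyclin C (Homo sapiens), read by TR-FRET, with a stated time of 1 h; a higher number here means a weaker inhibitor, a lower number a stronger inhibitor:
compound 1 `Nc1nccc(N2CC[C@H](NC(=O)Nc3ccc(Cl)c(C(F)(F)F)c3)C2)n1` gives 42.3 nM
compound 2 `CNc1nccc(N2CC[C@H](NC(=O)Nc3ccc(CN(C)C)c(C(F)(F)F)c3)C2)n1` gives 40.1 nM
compound 3 `CNc1nccc(N2CC[C@H](NC(=O)Nc3ccc(OC(F)(F)F)cc3)C2)n1` gives 44.1 nM

The three numbers sit close together. Compound 2 carries the lowest number of the three, but its gap to compound 1 and its gap to compound 3 both fall within the usual scatter of this assay, so no ordering among the three compounds can be read from these values. Among the measured compounds shown here, no two of the measured compounds differ from each other in a single place, so no single-change step is available to lean on.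

Compound 4 `CNc1nccc(N2CC[C@H](NC(=O)Nc3ccc(CN4CCCC4)c(C(F)(F)F)c3)C2)n1` has not yet been measured. It differs from compound 2 in one place: pyrrolidin-1-yl in place of dimethylamino on a saturated chain carbon bound to an aromatic carbon. The shared core, the urea and the trifluoromethyl group are carried over unchanged. For the measured compounds named here, nothing among the measured compounds tests this particular exchange, so the expectation rests on the unchanged remainder of the molecule and on the closeness of the three numbers already in hand. The expected step is a 1.0-fold higher number from compound 2 to compound 4 (0.02 log units; within the scatter), that is, no step beyond the scatter in either direction. Compound 4 is estimated at 42 nM in this assay, with a range from 16 nM to 110 nM.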

Compound 4, half-maximal inhibitory concentration: 157 nM
For compound 4 the middle estimate is 3.7-fold (0.57 log units) below the measured one, outside the stated range (above it).
By their numbers in this assay, from the lowest: compounds 2, 1 and 3 (each within the scatter of the next); then compound 4.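

In this assay, pyrrolidin-1-yl in place of dimethylamino on a saturated chain carbon bound to an aromatic carbon gives a 3.9-fold higher number from compound 2 to compound 4 (0.59 log units; beyond the scatter). Among the compounds shown here, this is the first single-change step, and it shows that the number responds to what is attached to the amine nitrogen at this position, even though the hydrogen-bond donor count, the acceptor count and the absence of net charge are all the same for the two groups. No measurement on hand bears on why this exchange raises the number.

This single step does not separate the closing of the ring from the larger number of heavy atoms, as the two arrive together in pyrrolidin-1-yl; diethylamino, an open-chain amine on the same carbon, and azetidin-1-yl, a smaller ring, would pull these two apart. Also open, as far as these compounds go, is whether a further atom in the ring is tolerated here, as in morpholin-4-yl, and whether a primary amine at this position would give a lower or higher number than the dimethylamino group of compound 2.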